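Aryl substituent variation on the shared core: methoxy to pyrrolidinyl

A few compounds are considered here, and "the series" means these few. Any claim that something is new, unique, unknown or untested is made for them only; others in the source may bear on it.

Measured so far:
compound 1 `OC1CCc2cccc(Nc3ncc(-c4ccccc4)o3)c2C1` — 187 nM
compound 2 `COc1ccc(-c2cnc(Nc3cccc4c3CC(O)CC4)o2)cc1` — 81 nM

In an in vitro functional assay on cells for antagonist activity at transient receptor potential cation channel subfamily V member 1 (Homo sapiens), read by FLIPR and calcium flux (on this read-out higher numbers stand for weaker inhibition and lower numbers for stronger inhibition), compound 2 gives the lowest of the two numbers; its nearest neighbour is compound 1, with a 2.3-fold lower number from compound 1 to compound 2 (0.36 log units; beyond the scatter). Compound 3 `OC1CCc2cccc(Nc3ncc(-c4ccc(N5CCCC5)cc4)o3)c2C1` differs from compound 2 by pyrrolidin-1-yl in place of methoxy on an aromatic carbon. Among the compounds with values here, the only measured step that bears on this position is the one from compound 1 to compound 2, which was modest but beyond the scatter. For compound 3 a change of similar or smaller size is expected in this assay, a 1.4-fold lower number from compound 2 to compound 3 (0.13 log units; within the scatter), most likely within the scatter. Compound 3 is estimated at 60 nM, range 15 nM to 250 nM.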

Compound 3, half-maximal inhibitory concentration: 101 nM
Beside the measured number, compound 3's estimate is 1.7-fold (0.23 log units) below it; measured number inside the range.
By their numbers in this assay, from the lowest: compounds 2, 3 and 1 (each within the scatter of the next, the first and the last beyond it).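

In this assay, the aromatic carbon para to a large group takes pyrrolidin-1-yl in place of methoxy with a 1.2-fold higher number from compound 2 to compound 3 (0.10 log units; within the scatter) even though a five-membered non-aromatic ring enters there. With hydrogen as the reference, the step is a 1.9-fold lower number from compound 1 to compound 3 (0.27 log units; within the scatter) so pyrrolidin-1-yl cannot be told apart from hydrogen here, although methoxy can. No measurement at hand accounts for either step.

Still open, on these data alone, is whether an open-chain dimethylamino group, a morpholine ring or a carboxylic acid at this place would separate from methoxy and hydrogen beyond the scatter.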